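Swapping chloro for nitro on the azo-linked phenyl ring

The compounds below may be only part of what the source reports. "The series", "measured", "known", "first", "only" and "open" are said of these compounds alone.

Measured so far:
- compound 1 `NC(=S)N1Nc2onc(-c3ccccc3)c2C1c1ccc(Cl)cc1`: 2.2 h
- compound 2 `Cc1nc(N2Nc3onc(-c4ccccc4)c3C2c2ccc(Cl)cc2)sc1/N=N/c1ccc(Cl)cc1`: 7.57 h

Both numbers come from an ADME assay on a cell-free system (plasma, Rattus norvegicus) for metabolic stability; a lower number here means that the compound disappears faster, a higher number that the compound lasts longer. Compound 2 holds the higher of the two, with 7.57 h; compound 1, at 2.2 h, sits clearly lower, by a gap beyond the usual scatter. For the measured compounds named here, the two share a core, but compound 2 carries a larger substituted group on one nitrogen of that core, and the two structures differ in more than one place, so no single step between them can be read off.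

Compound 3 `Cc1nc(N2Nc3onc(-c4ccccc4)c3C2c2ccc(Cl)cc2)sc1/N=N/c1ccc([N+](=O)[O-])cc1` is the next in line and has not yet been measured. It differs from compound 2 in one place: nitro in place of chloro on an aromatic carbon, para to a large group. Going by the values given here, no measured pair in this small set shows what such a swap does here, so the direction is open. The expectation is a change of about the size of the scatter, if any, with compound 3 estimated at 6 h (range 3 h to 12 h), which would mean a step of a 1.3-fold lower number from compound 2 to compound 3 (0.10 log units; within the scatter) in this assay.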

Compound 3, half-life: 6.08 h
Compound 3: the middle estimate sits 1.0-fold (0.01 log units) below what was measured; measured number inside the range.
By their numbers in this assay, from the lowest: compound 1; then compounds 3 and 2 (each within the scatter of the next).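

In this assay the swap from 4-chlorophenyl to 4-nitrophenyl gives a 1.2-fold lower number from compound 2 to compound 3 (0.10 log units; within the scatter) and so leaves the two compounds indistinguishable by this measurement. For the compounds shown here, this is the first comparison in the set between compounds that differ in only one place. It shows that, on this aromatic ring and para to a large group, nitro can stand in place of chloro with no difference that rises above the usual scatter of repeated measurements, although no information on the cause is available for this result.

Chloro and nitro are the only two groups compared at this position, so a single step cannot show how far the result extends, and an amine, a carboxylic acid or a methoxy group might behave quite differently here. On these data alone, compound 1 differs from the other two compounds in more than one place, so steps involving it cannot be read, and it remains open which part of the larger structure on the shared core matters for how long these compounds last.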